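Restoring a Methyl Group: What Compound 4 Might Show

The source may hold more compounds than are shown below. What is called first, only, known or untested is meant among the compounds shown, and "the series" means these compounds.

Of the compounds shown here, three sharing one core have been tested in a functional assay for inhibition, with a stated time of 30 min, tested at 1 mM; on this read-out higher numbers stand for more inhibition at the one concentration tested (going by the name of the read-out) and lower numbers for less inhibition. Compound 1 `COc1ccc(/C(Cl)=C/C=C(\C#N)C(=O)c2c(C)[nH]c3ccccc23)cc1` gives 34.2%. Compound 2 `COc1ccc(/C(Cl)=C/C=C(\C#N)C(=O)c2c[nH]c3ccccc23)cc1` gives 23.4%. Compound 3 `COc1ccc(/C(Cl)=C/C=C(\C#N)C(=O)c2c[nH]c3ccccc23)cc1OC` gives 15.8%, the lowest of the three numbers; its gap to compound 2 lies within the scatter, while the gap to compound 1 lies beyond it.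

Two single-change steps link these compounds. a number 10.8 percentage points lower from compound 1 to compound 2 (beyond the scatter), a modest drop beyond the scatter. a number 7.6 percentage points lower from compound 2 to compound 3 (within the scatter), a change within the scatter.

Compound 4 `COc1ccc(/C(Cl)=C/C=C(\C#N)C(=O)c2c(C)[nH]c3ccccc23)cc1OC` differs from compound 3 in one place: methyl in place of hydrogen on an aromatic carbon. This is the mirror image of the first step, where removing the methyl cost inhibition. Because a number 10.8 percentage points lower from compound 1 to compound 2 (beyond the scatter) lowered the number when the methyl left, putting the methyl back is expected to raise it by a similar amount. Compound 4 is therefore expected to give 26.6%, within a range from 15% to 38%. The expected step is a number 10.8 percentage points higher from compound 3 to compound 4 (beyond the scatter) in this assay.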

Compound 4, a percentage reported as inhibition, at one concentration (the size of the read-out at that concentration, not a potency): 22.4%
For compound 4 the middle estimate is 4.2 percentage points above the measured one, within the range that was stated.
By their numbers in this assay, from the lowest: compounds 3, 4 and 2 (each within the scatter of the next); then compound 1.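

On the core carrying the second methoxy, methyl in place of hydrogen on this aromatic carbon, next to the ring nitrogen, gives a number 6.6 percentage points higher from compound 3 to compound 4 (within the scatter), so this single step cannot be told apart from ordinary scatter. With the same change now seen on two cores, the two steps agree closely enough that the data give no sign of the methyl step depending on the core: the same change on two cores in this assay, a number 10.8 percentage points lower (beyond the scatter) from compound 1 to compound 2 and a number 6.6 percentage points lower (within the scatter) from compound 4 to compound 3, 4.2 percentage points apart, within the scatter of two such steps. The methoxy change can also now be read on the methyl-bearing core, where it gives a number 11.8 percentage points lower from compound 1 to compound 4 (beyond the scatter), and it too agrees with its earlier step: the same change on two cores in this assay, a number 7.6 percentage points lower (within the scatter) from compound 2 to compound 3 and a number 11.8 percentage points lower (beyond the scatter) from compound 1 to compound 4, 4.2 percentage points apart, within the scatter of two such steps.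

Going by these compounds, only hydrogen and methyl appear at this position, so the effect of an ethyl group, a longer chain or an amine there remains open. Each number also comes from a single concentration, leaving potency unknown.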